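Lengthening the acrylamide chain on a shared kinase-inhibitor core

A few compounds are considered here, and "the series" means these few. Any claim that something is new, unique, unknown or untested is made for them only; others in the source may bear on it.

Measured so far:
compound 1 `C=C(F)C(=O)Nc1cc(Nc2nccc(-c3cn(C)c4ccccc34)n2)c(OC)cc1N(C)CCN(C)C` — 4230 nM
compound 2 `CC/C=C\C(=O)Nc1cc(Nc2nccc(-c3cn(C)c4ccccc34)n2)c(OC)cc1N(C)CCN(C)C` — 3860 nM

The two compounds share a core and differ only in the group on the carbonyl carbon of the amide. In a functional assay on NCI-H1975 cells (Homo sapiens) for antiproliferative activity, read by MTT assay, with a stated time of 72 h (on this read-out higher numbers stand for weaker inhibition and lower numbers for stronger inhibition), compound 1 gives 4230 nM, and compound 2 gives 3860 nM. Among the measured compounds shown here, the only step measured between them, a 1.1-fold lower number from compound 1 to compound 2 (0.04 log units; within the scatter), shows that exchanging 1-fluoroethenyl for but-1-en-1-yl left the read-out essentially unchanged. Compound 2 thus carries the lowest of the two numbers, but its gap to compound 1 lies within the scatter, so no order between them can be claimed.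

Compound 3 `CCC/C=C\C(=O)Nc1cc(Nc2nccc(-c3cn(C)c4ccccc34)n2)c(OC)cc1N(C)CCN(C)C` is the next point on this path. The change from compound 2 is methyl in place of hydrogen on a saturated chain carbon, two bonds along the chain from a double-bonded chain carbon, which is the same kind of chain extension already walked from compound 1 to compound 2. That earlier step was within the scatter, so the expected step of a 1.0-fold lower number from compound 2 to compound 3 (0.01 log units; within the scatter) is likewise no change beyond the scatter. Compound 3 is therefore estimated at 3800 nM, with a range from 1800 nM to 8000 nM.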

Compound 3, half-maximal inhibitory concentration: 1220 nM
Compound 3: the middle estimate sits 3.1-fold (0.49 log units) above what was measured; measured number outside the range, below it.
By their numbers in this assay, from the lowest: compound 3; then compounds 2 and 1 (each within the scatter of the next).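

In this assay, methyl in place of hydrogen on a saturated chain carbon, two bonds along the chain from a double-bonded chain carbon, gives a 3.2-fold lower number from compound 2 to compound 3 (0.50 log units; beyond the scatter) and so shows that this position can register a change of a single carbon, which the earlier pair had not revealed. Pent-1-en-1-yl in place of 1-fluoroethenyl on the carbonyl carbon gives a 3.5-fold lower number from compound 1 to compound 3 (0.54 log units; beyond the scatter) and thus separates two groups on this carbon by more than the scatter, whereas but-1-en-1-yl and 1-fluoroethenyl had stayed within it, so among these three compounds a difference appears only with pent-1-en-1-yl. Nothing available here accounts for the effect of this one methyl on the read-out.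

As far as these compounds go, with only these three groups on the carbonyl carbon, it remains open whether the lower number would persist, deepen or reverse with a longer chain such as hex-1-en-1-yl. From the compounds shown here alone, it is equally open whether the gain depends on a plain carbon chain or would survive a branched chain or an amine at the end of the chain.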